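A few compounds are considered here, and "the series" means these few. Any claim that something is new, unique, unknown or untested is made for them only; others in the source may bear on it.

Measured compounds:
compound 2 `CNC(=O)c1cc(Oc2ccc(C(=O)/C=C/c3cccc(Br)c3)cc2)ccn1`: 3400 nM
compound 3 `CNC(=O)c1cc(Oc2ccc(C(=O)/C=C/c3ccc(Br)cc3)cc2)ccn1`: 18500 nM
compound 1 `CNC(=O)c1cc(Oc2ccc(/C=C/C(=O)c3ccc([N+](=O)[O-])cc3)cc2)ccn1`: "not determined" (no result reported)

The series is followed in a functional assay on PC-3 cells (Homo sapiens) for cytotoxicity, read by MTT assay, with a stated time of 72 h; on this read-out higher numbers stand for weaker inhibition and lower numbers for stronger inhibition. Compound 1 has no single number in this assay; no result was reported for it, so it stands nowhere on the numbers shown. Compound 4 `CNC(=O)c1cc(Oc2ccc(/C=C/C(=O)c3ccc(Br)cc3)cc2)ccn1` differs from compound 1 by bromo in place of nitro on an aromatic carbon.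

For the measured compounds named here, the only measured step, a 5.4-fold higher number from compound 2 to compound 3 (0.74 log units; beyond the scatter), replaces 3-bromophenyl by 4-bromophenyl rather than nitro by bromo, and in both of its compounds the carbonyl is placed differently along the double-bonded chain than in compound 4. It therefore does not bear directly on the step from compound 1 to compound 4, and with no value for compound 1 no size or direction can be set for that step in this assay. Compound 4 does share its 4-bromophenyl with compound 3, which gives 18500 nM, and the spread from compound 2 at 3400 nM to compound 3 marks the region where a value seems most plausible. For compound 4 a value of about 8000 nM is expected, with a range from 2000 nM to 40000 nM.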

Compound 4, half-maximal inhibitory concentration: 3560 nM
The estimate for compound 4 lay 2.2-fold (0.35 log units) above the measured number; measured number inside the range.
By their numbers in this assay, from the lowest: compounds 2 and 4 (each within the scatter of the next); then compound 3.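

In this assay, for the compounds shown here, compound 4 gives 3560 nM, but compound 1 has no single number, so no step from compound 1 to compound 4 can be read. The compounds shown leave open how 4-bromophenyl compares with 4-nitrophenyl on this core in this assay. No supporting data bear on this result.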